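Aryl swap at the double-bonded chain carbon

This account rests on a few compounds, and the source may have more. Where it says the series, first, only, none or still open, it means among the compounds named here.

Measured so far in a functional assay on PC-3 cells (Homo sapiens) for cytotoxicity, read by MTT assay, with a stated time of 72 h; a higher number here means a weaker inhibitor, a lower number a stronger inhibitor:
compound 1, `COc1cc(C(=O)c2cc(OC)c(OC)c(OC)c2)cc(NC(=O)/C=C/c2cc(OC)c(OC)c(OC)c2)c1OC`: 4800 nM
compound 2, `C#CCOc1cccc(/C=C/C(=O)Nc2cc(C(=O)c3cc(OC)c(OC)c(OC)c3)cc(OC)c2OC)c1`: 10100 nM

Compound 2 stands highest of the two numbers in this assay; its nearest neighbour is compound 1, with a 2.1-fold higher number from compound 1 to compound 2 (0.32 log units; beyond the scatter). Compound 3 is `COc1cc(C(=O)c2cc(OC)c(OC)c(OC)c2)cc(NC(=O)/C=C/c2ccc(F)cc2)c1OC` and differs from compound 2 by 4-fluorophenyl in place of 3-(propargyloxy)phenyl on a double-bonded chain carbon bound to a double-bonded chain carbon. Going by the values given here, only that single step touches this position, and it concerns a different aryl; it gives no direct read on a 4-fluorophenyl. The expectation for compound 3 is therefore a number close to compound 2, with a 1.4-fold lower number from compound 2 to compound 3 (0.16 log units; within the scatter) as a small estimated shift. Compound 3 is estimated at 7000 nM, range 2500 nM to 20000 nM.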

Compound 3, half-maximal inhibitory concentration: 4100 nM
Compound 3: the middle estimate sits 1.7-fold (0.23 log units) above what was measured; the measured number falls inside the stated range.
By their numbers in this assay, from the lowest: compounds 3 and 1 (each within the scatter of the next); then compound 2.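

In this assay, the step from 3-(propargyloxy)phenyl to 4-fluorophenyl on a double-bonded chain carbon bound to a double-bonded chain carbon gives a stronger reading (a 2.5-fold lower number from compound 2 to compound 3 (0.39 log units; beyond the scatter)). Against 3,4,5-trimethoxyphenyl, the 4-fluorophenyl group shows no separation (a 1.2-fold lower number from compound 1 to compound 3 (0.07 log units; within the scatter)), so among these three aryl groups only 3-(propargyloxy)phenyl stands apart. No measured evidence here accounts for these readings. Open, on these data alone, is whether an amine or a carboxylic acid in place of the fluorine would keep the reading level with compound 3. As far as these compounds go, an unsubstituted phenyl at this position also remains open.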